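Series notes: cyclopentyl to propyl, compound 3 to compound 4

The source may hold more compounds than are shown below. What is called first, only, known or untested is meant among the compounds shown, and "the series" means these compounds.

Measured so far in a functional assay on NUGC-3 cells (Homo sapiens) for antiproliferative activity, read by sulforhodamine B assay; a higher number here means a weaker inhibitor of growth, a lower number a stronger inhibitor of growth:
compound 1 `O=C(/C=C/c1ccc(O)cc1)c1c(O)cccc1OCCC1CCCC1`: 3200 nM
compound 2 `CC(C)(C)CCOc1cccc(O)c1C(=O)/C=C/c1ccc(C(=O)O)cc1`: 5440 nM
compound 3 `O=C(/C=C/c1ccc(O)cc1)c1c(O)cccc1OCC1CCCC1`: 2140 nM

Among the three numbers in this assay, compound 3 has the lowest. Compound 1 is nearest to it, the step being a 1.5-fold lower number from compound 1 to compound 3 (0.17 log units; within the scatter). Among the compounds with values here, compound 2 lies furthest away, its number higher than that of compound 3 by a margin beyond the scatter; no single-place step connects compound 2 to the others, so only the two values are set side by side. Compound 3 therefore sits at the low end of the set without being separated from compound 1.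

Compound 4 `CCCCOc1cccc(O)c1C(=O)/C=C/c1ccc(O)cc1` is not yet measured in this assay. Its difference from compound 3: propyl in place of cyclopentyl on a saturated chain carbon bound to an oxygen on an aromatic ring. Within the data shown here, the one measured step that bears on this place is a 1.5-fold lower number from compound 1 to compound 3 (0.17 log units; within the scatter), which exchanged cyclopentylmethyl for cyclopentyl on a saturated chain carbon bound to an oxygen on an aromatic ring and stayed within the scatter. Nothing measured speaks to a chain without a ring on that carbon, so the expectation rests on that step alone. The expected step is a 1.4-fold higher number from compound 3 to compound 4 (0.15 log units; within the scatter), a slight drift toward a higher number and not beyond the scatter. Compound 4 is estimated at 3000 nM, with a range from 1200 nM to 8000 nM.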

Compound 4, concentration for 50% growth inhibition: > 30000 nM
Compound 4 ended at the assay's limit (the forecaster's own chance of this, stated with the estimate: 5%); middle value at least 10-fold (1.00 log units) from the limit.
By their numbers in this assay, from the lowest: compounds 3, 1 and 2 (each within the scatter of the next, the first and the last beyond it). At a limit, above all of these: compound 4.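

In this assay compound 4 stands at a limit and not at a number: the limit of > 30000 nM in this assay, at which 1 of the 4 values shown sits. Where the exchange of cyclopentylmethyl for cyclopentyl, a 1.5-fold lower number from compound 1 to compound 3 (0.17 log units; within the scatter), left the value within the scatter, removing the ring at this same place is a change of another order: an at least 14-fold higher number from compound 3 to compound 4 (1.14 log units; beyond the scatter), and an at least 9.3-fold higher number from compound 1 to compound 4 (0.97 log units; beyond the scatter). The saturated chain carbon bound to an oxygen on an aromatic ring is therefore not indifferent to what it carries: the ring-bearing groups of compound 1 and compound 3 cannot be told apart, while the butyl group of compound 4 stands clearly apart from both, a contrast that rests on these three compounds alone.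

On these data alone, how far growth inhibition depends on the ring itself, and how far on the number of carbons in the group, stays open; a longer chain such as hexyl, or a cyclopropylmethyl or cyclohexylmethyl group, would separate the two. As far as these compounds go, whether an amine or a carboxylic acid at the end of the chain is accepted at this place is equally open.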